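Sulfur to Selenium: One Atom Change on Compound 3

A few compounds are considered here, and "the series" means these few. Any claim that something is new, unique, unknown or untested is made for them only; others in the source may bear on it.

Compound 3 `CSc1ccc2ccccc2n1` gives no number in a functional assay on MCF7 cells (Homo sapiens) for cytotoxicity, read by MTT assay, with a stated time of 72 h; a lower number here means a stronger inhibitor of growth, a higher number a weaker inhibitor of growth: it sits at the limit > 100000 nM, the point where the assay stops counting, as the limit of > 100000 nM in this assay, at which 1 of the 3 values shown sits, records. Compound 1 `[SeH]c1nc2ccccc2s1` also stops at a limit, > 50000 nM. Compound 2 `[SeH]c1ccnc([SeH])n1` reaches a measured value of 6700 nM, and it alone carries selenol groups on a different core. Compound 4 `C[Se]c1ccc2ccccc2n1` alters compound 3 in one spot: a group of 2 heavy atoms (1 carbon, 1 selenium; no ring) in place of a group of 2 heavy atoms (1 carbon, 1 sulfur; no ring), on an aromatic carbon. Among the measured compounds shown here, no measured pair shows this exact swap, so the step is judged from the structures alone. A methylselanyl is not a selenol, and compound 4 is expected to remain weak, with the step of an at least 1.4-fold lower number from compound 3 to compound 4 (0.15 log units; that floor lies within the scatter) expected to be small, within the scatter. Compound 4 is estimated at 70000 nM, between 15000 nM and 200000 nM.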

Compound 4, concentration for 50% growth inhibition: 21000 nM
Compound 4: the middle estimate sits 3.3-fold (0.52 log units) above what was measured, and the stated range covers the measured number.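

At this position, on an aromatic carbon next to the ring nitrogen, replacing methylsulfanyl with its selenium counterpart gives an at least 4.7-fold lower number from compound 3 to compound 4 (0.67 log units; beyond the scatter) in this assay. Compound 4 also reaches a measured value without carrying a selenol group. The true size of the step stays unknown, since compound 3 holds only a limit and not a number: the limit of > 100000 nM in this assay, at which 1 of the 4 values shown sits.

The compounds shown leave open how a longer chain on selenium, such as ethyl, or an amine in the same place would compare. Going by these compounds, whether this step carries over to other cores also remains open.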